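The source may hold more compounds than are shown below. What is called first, only, known or untested is meant among the compounds shown, and "the series" means these compounds.

Working notes on the series. In an assay on isolated protein for inhibition of Long-chain-fatty-acid--CoA ligase 1 (Homo sapiens), read by mass spectrometry, with a stated time of 90 min, in the presence of a further agent that is not named here (a higher number here means a weaker inhibitor, a lower number a stronger inhibitor), compound 1 `Cc1cccc(Cc2cc3cc(O[C@H]4CC[C@@H](C(=O)O)CC4)ccc3n2C)c1` gives 400 nM, and compound 2 `Cc1cccc(Cc2c(C(N)=O)c3cc(O[C@H]4CC[C@@H](C(=O)O)CC4)ccc3n2C)c1` gives 600 nM. For the measured compounds named here, the one step that has been measured, a 1.5-fold higher number from compound 1 to compound 2 (0.18 log units; within the scatter), leaves the two compounds within the scatter of each other; on the numbers so far compound 2 therefore carries the higher of the two readings, but the gap to compound 1 is not one to read anything into.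

Compound 3 `Cc1cccc(Cc2c(C#N)c3cc(O[C@H]4CC[C@@H](C(=O)O)CC4)ccc3n2C)c1` is the next member. It differs from compound 2 by cyano in place of carbamoyl on an aromatic carbon. Going by the values given here, no measured step bears directly on this exchange; the only comparison at that position, a 1.5-fold higher number from compound 1 to compound 2 (0.18 log units; within the scatter), shows that putting carbamoyl onto the bare carbon left the reading within the scatter, which suggests that this carbon tolerates a small substituent without a large move in either direction. Nothing here argues for a step beyond the scatter, so the reading of compound 3 in this assay is expected near that of compound 2, with a step of about a 1.2-fold lower number from compound 2 to compound 3 (0.08 log units; within the scatter). The estimate for compound 3 is 500 nM, with a range from 200 nM to 1500 nM.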

Compound 3, half-maximal inhibitory concentration: 1900 nM
Beside the measured number, compound 3's estimate is 3.8-fold (0.58 log units) below it; the measured number lies above the stated range.
By their numbers in this assay, from the lowest: compounds 1 and 2 (each within the scatter of the next); then compound 3.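

The aromatic carbon of the five-membered aromatic ring does not accept every small substituent alike: the exchange of carbamoyl for cyano gives a 3.2-fold higher number from compound 2 to compound 3 (0.50 log units; beyond the scatter), whereas putting carbamoyl onto the bare carbon gave only a 1.5-fold higher number from compound 1 to compound 2 (0.18 log units; within the scatter). Cyano also stands apart from the bare carbon, with a 4.8-fold higher number from compound 1 to compound 3 (0.68 log units; beyond the scatter), so of the two substituents seen here only cyano moves the reading beyond the scatter, and what this carbon tolerates depends on the group and not merely on the presence of a small substituent. The two groups differ by a triple bond in place of a double bond and by the hydrogen-bond donor that carbamoyl has and cyano lacks, but nothing available ties the step to either difference.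

The compounds shown leave open how other groups on this carbon would read, for instance a carboxylic acid, a methyl ester, an aminomethyl group or a single fluorine, and so whether cyano is an isolated case. They also leave open whether the step from carbamoyl to cyano holds when the 3-methylbenzyl group gives way to an unsubstituted benzyl or a cyclohexylmethyl group.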